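The source may hold more compounds than are shown below. What is called first, only, known or untested is meant among the compounds shown, and "the series" means these compounds.

Working notes on the series, read in a functional assay on HeLa cells (Homo sapiens) for inhibition, read by MTT assay, with a stated time of 72 h; on this read-out lower numbers stand for stronger inhibition and higher numbers for weaker inhibition. Compound 3 `CC(C)C[C@H](NC(=O)CCC[C@H](NC(=O)CNC(=O)OC(C)(C)C)C(=O)NCc1ccc2ccccc2c1)B(O)O` stands at > 10000 nM, which is a limit and not a number. Compound 1 `CC(C)C[C@H](NC(=O)CCC[C@H](NC(=O)OC(C)(C)C)C(=O)NCc1ccc2ccccc2c1)B(O)O` gives > 10000 nM, likewise a limit. These two entries make up (the limit of > 10000 nM in this assay, at which 2 of the 3 values shown sit). For the measured compounds named here, compound 2 `CC(C)C[C@H](NC(=O)CC[C@H](NC(=O)[C@H](C)NC(=O)OC(C)(C)C)C(=O)NCc1ccc2ccccc2c1)B(O)O` is the only compound so far with a number, 2350 nM.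

Compound 4 `CC(C)C[C@H](NC(=O)CCC[C@H](NC(=O)[C@H](C)NC(=O)OC(C)(C)C)C(=O)NCc1ccc2ccccc2c1)B(O)O` comes from compound 3 by methyl in place of hydrogen on a saturated chain carbon bound to an amide-type nitrogen and a carbonyl carbon. This turns ((tert-butoxycarbonyl)amino)methyl into 1-((tert-butoxycarbonyl)amino)ethyl.

Going by the values given here, the only measured step that bears on this is a step that the two limits leave unreadable from compound 1 to compound 3, and it fixes no size. Though it differs from compound 4 elsewhere in the chain, compound 2 also carries the 1-((tert-butoxycarbonyl)amino)ethyl group, and compound 2 at 2350 nM is the one numerical guide. A move toward stronger inhibition is therefore expected, of loosely known size, and the outcome may again be only a limit.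

The expected change is an at least 1.4-fold lower number from compound 3 to compound 4 (0.15 log units; that floor lies within the scatter), an estimate and no more. For compound 4 the estimated value is 7000 nM, with an expected range of 2000 nM to 20000 nM.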

Compound 4, half-maximal inhibitory concentration: > 10000 nM
Compound 4 was reported as a limit (the forecaster's own chance of this, stated with the estimate: 45%); at least 1.4-fold (0.15 log units) between middle value and limit.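

In this assay compound 4 gives > 10000 nM which is a limit and not a number, so the 1-((tert-butoxycarbonyl)amino)ethyl group does not by itself bring a measurable value to the chain of compound 3. For the compounds shown here, the one readable step is an at least 4.2-fold higher number from compound 2 to compound 4 (0.62 log units; beyond the scatter) and it goes with a group of 12 heavy atoms in place of a group of 11 heavy atoms, on a saturated chain carbon, three bonds along the chain from an amide-type nitrogen and a carbonyl carbon, which places the only measured difference so far in that chain and not in the methyl. The steps from compound 1 and from compound 3 to compound 4 cannot be read, and most of the series now rests on a single limit: the limit of > 10000 nM in this assay, at which 3 of the 4 values shown sit.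

On these data alone, how far compound 1, compound 3 and compound 4 lie beyond that limit stays open, and with it whether methyl in place of hydrogen changes anything on this chain. Also open, as far as these compounds go, is how an amine or a carboxylic acid in place of the tert-butoxycarbonyl-capped end would read on the chain of compound 2.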